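Aryl Swaps on the Ring Amine Nitrogen: Compound 4 Expected

The source may report more compounds than this note shows. Statements on the series, on what has been measured and on what is new or still open speak of the compounds shown alone.

Measured compounds:
Compound 1 `Nc1scc(CN2CCN(c3cc(Cl)cc(Cl)c3)CC2)c1C(=O)c1ccc(Cl)cc1` — -74%
Compound 2 `Nc1scc(CN2CCN(c3cccc(C(F)(F)F)c3)CC2)c1C(=O)c1ccc(Cl)cc1` — -80%
Compound 3 `Nc1scc(CN2CCN(c3ccc(OC(F)(F)F)cc3)CC2)c1C(=O)c1ccc(Cl)cc1` — -74%

In a functional assay on CHO cells with adenosine receptor A1 (Homo sapiens) as the target, read by cAMP accumulation and immunoassay, with a stated time of 6 min, tested at 10 uM (on this read-out higher numbers stand for a weaker effect at the one concentration tested and lower numbers for a stronger effect), compound 1 gives -74%, compound 2 gives -80% and compound 3 gives -74%. Compound 3 stands level with compound 1 at the digits given, the two together the highest of the three numbers; its nearest neighbour is compound 1 with no change at the digits printed from compound 1 to compound 3 (within the scatter), its furthest compound 2 with a number 6 percentage points higher from compound 2 to compound 3 (within the scatter). Compound 4 `Nc1scc(CN2CCN(c3cccc(F)c3)CC2)c1C(=O)c1ccc(Cl)cc1` differs from compound 3 only on the ring amine nitrogen: 3-fluorophenyl in place of 4-(trifluoromethoxy)phenyl on an amine nitrogen in a ring. The three steps that bear on this change, a number 6 percentage points lower from compound 1 to compound 2 (within the scatter), no change at the digits printed from compound 1 to compound 3 (within the scatter) and a number 6 percentage points higher from compound 2 to compound 3 (within the scatter), all vary the same aryl group and all stay within the scatter. Compound 4 is therefore expected to show no change at the digits printed from compound 3 to compound 4 (within the scatter), no shift beyond the scatter. Compound 4 is estimated at -74%, within -88% to -60%.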

Compound 4, a percentage reported as activity, at one concentration (the size of the read-out at that concentration, not a potency): -82%
Estimate against measurement, compound 4: 8 percentage points above; measured number inside the range.
By their numbers in this assay, from the lowest: compounds 4, 2, 1 and 3 (each within the scatter of the next).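

In this assay, 3-fluorophenyl on the amine nitrogen in the ring gives no step beyond the scatter against any of the three earlier aryl groups: a number 8 percentage points lower from compound 3 to compound 4 (within the scatter) and a number 8 percentage points lower from compound 1 to compound 4 (within the scatter) and a number 2 percentage points lower from compound 2 to compound 4 (within the scatter). The position thus also accommodates an aryl group with a lone fluoro and no hydrogen-bond acceptor, without leaving the scatter. No evidence on the cause accompanies these values. The compounds shown leave open whether an amine or a carboxylic acid on this phenyl ring would move the read-out beyond the scatter.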